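This account rests on a few compounds, and the source may have more. Where it says the series, first, only, none or still open, it means among the compounds named here.

Measured so far in a functional assay on HCT-116 cells (Homo sapiens) for antiproliferative activity, read by MTT assay, with a stated time of 48 h; a higher number here means a weaker inhibitor, a lower number a stronger inhibitor:
- compound 1 `CCCCCC(CCO)n1cnc2c(N(C)C)ncnc21`: > 50000 nM, a limit of the assay and not a number
- compound 2 `CCCCCCCCC(CCO)n1cnc2c(N(C)C)ncnc21`: 19800 nM
- compound 3 `CCCCCCCCCCC(CCO)n1cnc2c(N(C)C)ncnc21`: 5490 nM

Compound 3 has the lowest value of the three, which makes it the strongest inhibitor here, and compound 2 holds the nearest measured number. Compound 4 `CCCCCCCCCCCC(CCO)n1cnc2c(N(C)C)ncnc21` makes one change to compound 3: methyl in place of hydrogen on a saturated chain carbon, ten or more bonds along the chain from an aromatic nitrogen. Three measured steps lengthen this same chain, and all of them lead to lower numbers: an at least 2.5-fold lower number from compound 1 to compound 2 (0.40 log units; beyond the scatter), an at least 9.1-fold lower number from compound 1 to compound 3 (0.95 log units; beyond the scatter) and a 3.6-fold lower number from compound 2 to compound 3 (0.56 log units; beyond the scatter). The first two start from a limit, so only the last has a true size, and it is the closest guide. That step added ethyl, whereas this change adds only methyl, so a smaller step in the same direction is expected in this assay, perhaps not far beyond the scatter. The expected step is a 1.7-fold lower number from compound 3 to compound 4 (0.23 log units; within the scatter). For compound 4 the estimated value is 3200 nM, with an expected range of 1500 nM to 6500 nM.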

Compound 4, half-maximal inhibitory concentration: 12000 nM
For compound 4 the middle estimate is 3.8-fold (0.57 log units) below the measured one; the measured number lies above the stated range.
By their numbers in this assay, from the lowest: compound 3; then compounds 4 and 2 (each within the scatter of the next). At a limit, above all of these: compound 1.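

In this assay, for the compounds shown here, lengthening this chain no longer keeps lowering the number: adding methyl gives a 2.2-fold higher number from compound 3 to compound 4 (0.34 log units; beyond the scatter), the first upward step, which leaves compound 3 as the strongest inhibitor of the four. The gain from the longer chain is not clearly kept either, since a 1.7-fold lower number from compound 2 to compound 4 (0.22 log units; within the scatter) is a gap that leaves those two compounds level in this assay. Compound 1 stands at a limit, so an at least 4.1-fold lower number from compound 1 to compound 4 (0.61 log units; beyond the scatter) gives only a bound on the size of that step: the limit of > 50000 nM in this assay, at which 1 of the 4 values shown sits.

Going by these compounds, with a single compound past compound 3, it remains open whether the rise continues or is a one-off. Also open, on these data alone, is what a longer chain, or an amine in place of the added methyl, would do.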